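The source may hold more compounds than are shown below. What is called first, only, known or untested is meant among the compounds shown, and "the series" means these compounds.

Series on the shared core of compound 1 `CN1C[C@H](C(=O)Nc2ccc(C#N)cc2)[C@@H](c2ccc(/C=C/C(=O)Nc3ccccc3N)cc2)C1`, with compound 2 `CN1C[C@H](C(=O)Nc2ccc(C3CC3)cc2)[C@@H](c2ccc(/C=C/C(=O)Nc3ccccc3N)cc2)C1` and compound 3 `CN1C[C@H](C(=O)Nc2ccc(Cl)cc2F)[C@@H](c2ccc(/C=C/C(=O)Nc3ccccc3N)cc2)C1` varying the group on the amide-type nitrogen. In an in vitro ADME assay on microsomes from liver (Mus musculus) for pharmacokinetics, read by LC-MS, with a stated time of 10 min, tested at 1 uM (a higher number here means faster removal of the compound, a lower number slower removal), compound 1 gives 35 mL/min/kg, compound 2 gives 60 mL/min/kg and compound 3 gives 43 mL/min/kg. The steps of a 1.7-fold higher number from compound 1 to compound 2 (0.23 log units; within the scatter) and a 1.4-fold lower number from compound 2 to compound 3 (0.14 log units; within the scatter) both stay within the scatter, so compound 2 is not set apart from compound 1 or compound 3; the step of a 1.2-fold higher number from compound 1 to compound 3 (0.09 log units; within the scatter) is likewise within the scatter. Compound 4 `CN1C[C@H](C(=O)NC2CCCC2)[C@@H](c2ccc(/C=C/C(=O)Nc3ccccc3N)cc2)C1` carries the change (cyclopentyl in place of 4-cyclopropylphenyl on an amide-type nitrogen). Each measured step sits at the same amide-type nitrogen and none moved the number beyond the scatter, so no step beyond the scatter is expected in this assay. Compound 4 is therefore estimated at 45 mL/min/kg, range 22 mL/min/kg to 90 mL/min/kg, an expected step of a 1.3-fold lower number from compound 2 to compound 4 (0.12 log units; within the scatter).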

Compound 4, clearance: 61 mL/min/kg
Beside the measured number, compound 4's estimate is 1.4-fold (0.13 log units) below it; low and high end bracket the measured number.
By their numbers in this assay, from the lowest: compounds 1, 3, 2 and 4 (each within the scatter of the next).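

In this assay, cyclopentyl on the amide-type nitrogen gives a 1.0-fold higher number from compound 2 to compound 4 (0.01 log units; within the scatter) and a 1.4-fold higher number from compound 3 to compound 4 (0.15 log units; within the scatter) and a 1.7-fold higher number from compound 1 to compound 4 (0.24 log units; within the scatter) with all three steps within the scatter. Going by these compounds alone, a non-aromatic ring of carbon only therefore sits at this nitrogen with no step beyond the scatter, whereas the earlier compounds all carried a six-membered aromatic ring there. No measurement is available that bears on the reason for this result.

As far as these compounds go, whether an amine, a carboxylic acid or a longer chain on this nitrogen would stay within the scatter remains open. Also open, from the compounds shown here alone, is whether any group at this position moves the number beyond it.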